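The source may hold more compounds than are shown below. What is called first, only, known or untested is meant among the compounds shown, and "the series" means these compounds.

Compound 2 `O=C(Nc1cccc(-c2oc3cc(-c4ccc(F)cc4)ccc3c(=O)c2O)c1)c1ccc(Cl)cc1` carries the shared core with a 4-chlorophenyl on the carbonyl carbon of its amide. In a functional assay on GTL 16 cells for antiproliferative activity against GTL 16 cell line (Homo sapiens), read by CCK-8 assay, with a stated time of 72 h (a higher number here means a weaker inhibitor, a lower number a stronger inhibitor), compound 2 gives 9140 nM, the lowest of the three numbers measured, though the gap to compound 1 `O=C(Nc1cccc(-c2oc3cc(-c4ccc(F)cc4)ccc3c(=O)c2O)c1)c1ccccc1F` lies within the scatter: compound 1 gives 17400 nM in this assay, a step of a 1.9-fold lower number from compound 1 to compound 2 (0.28 log units; within the scatter). Compound 3 `CCc1ccc(C(=O)Nc2cccc(-c3oc4cc(-c5ccc(F)cc5)ccc4c(=O)c3O)c2)cc1` gives 24600 nM, and the step of a 2.7-fold higher number from compound 2 to compound 3 (0.43 log units; beyond the scatter) is the only one here that reaches beyond the scatter; the step of a 1.4-fold higher number from compound 1 to compound 3 (0.15 log units; within the scatter) does not.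

Compound 4 `Cc1cc(C(=O)Nc2cccc(-c3oc4cc(-c5ccc(F)cc5)ccc4c(=O)c3O)c2)ccc1F` has not yet been measured. It differs from compound 2 in one place: 4-fluoro-3-methylphenyl in place of 4-chlorophenyl on a carbonyl carbon. Among the compounds with values here, two measured steps bear on this change. The step from compound 1 to compound 2 shows that swapping one halogenated phenyl for another on this carbonyl carbon stays within the scatter, while the step from compound 2 to compound 3 shows that putting a small alkyl in place of chloro on the aromatic ring costs a modest amount. Compound 4 keeps a halogen and adds a methyl, so a small step toward a higher number, a 1.4-fold higher number from compound 2 to compound 4 (0.15 log units; within the scatter), is expected, most likely within the scatter. Compound 4 is therefore estimated at 13000 nM, with a range from 5500 nM to 31000 nM.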

Compound 4, half-maximal inhibitory concentration: 12100 nM
Estimate against measurement, compound 4: 1.1-fold (0.03 log units) above, and the stated range covers the measured number.
By their numbers in this assay, from the lowest: compounds 2, 4, 1 and 3 (each within the scatter of the next, the first and the last beyond it).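

In this assay, the 4-fluoro-3-methylphenyl on the carbonyl carbon cannot be told apart from the 4-chlorophenyl (a 1.3-fold higher number from compound 2 to compound 4 (0.12 log units; within the scatter)) or from the 2-fluorophenyl (a 1.4-fold lower number from compound 1 to compound 4 (0.16 log units; within the scatter)), so three halogen-bearing phenyl groups at this position now sit within the scatter of one another. Against the 4-ethylphenyl, the change gives a second step beyond the scatter (a 2.0-fold lower number from compound 3 to compound 4 (0.31 log units; beyond the scatter)), alongside the earlier one (a 2.7-fold higher number from compound 2 to compound 3 (0.43 log units; beyond the scatter)), although compound 3 and compound 1 remain within the scatter of each other. Nothing measured here gives a cause for these differences.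

Going by these compounds, all four compounds carry a substituted phenyl on this carbonyl carbon, so it remains open how an amine, a carboxylic acid or a longer chain on that ring would read. Also open, on these data alone, is what the methyl and the fluoro of compound 4 each contribute alone.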